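A few compounds are considered here, and "the series" means these few. Any claim that something is new, unique, unknown or untested is made for them only; others in the source may bear on it.

In a functional assay on DU-145 cells (Homo sapiens) for cytotoxicity, read by CCK-8 assay and cell counting, with a stated time of 2 days (on this read-out lower numbers stand for stronger inhibition and higher numbers for weaker inhibition), compound 2 `Oc1cccc(-c2cc(-c3ccc(Cl)cc3)nc(-c3ccsc3)c2)c1` gives 11600 nM, and compound 1 `Oc1cccc(-c2cc(-c3ccc(Cl)cc3)nc(-c3cccs3)c2)c1` gives 11600 nM; the change between them, (thiophen-2-yl in place of thiophen-3-yl on an aromatic carbon), made no change at the digits printed from compound 2 to compound 1 (within the scatter). Compound 3 `Oc1cccc(-c2cc(-c3ccsc3)nc(-c3cccc(Cl)c3)c2)c1` gives 3330 nM; its core differs from the core of compound 2 by 3-chlorophenyl in place of 4-chlorophenyl on an aromatic carbon, and that change made a 3.5-fold lower number from compound 2 to compound 3 (0.54 log units; beyond the scatter). Compound 4 `Oc1cccc(-c2cc(-c3cccc(Cl)c3)nc(-c3cccs3)c2)c1` has not yet been measured in this assay. Among the measured compounds shown here, it differs from compound 3 by thiophen-2-yl in place of thiophen-3-yl on an aromatic carbon, the same kind of change as the one that turned compound 2 into compound 1, though in compound 1 the place is meta to a 4-chlorophenyl group while in compound 4 it is meta to a 3-chlorophenyl group. Because the earlier change made no change at the digits printed from compound 2 to compound 1 (within the scatter), the corresponding step is expected to be a 1.1-fold higher number from compound 3 to compound 4 (0.02 log units; within the scatter), within the scatter. Compound 4 is therefore estimated at 3500 nM, between 1500 nM and 8000 nM.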

Compound 4, half-maximal inhibitory concentration: 2650 nM
Compound 4: middle estimate off by 1.3-fold (0.12 log units), on the high side; the range from low to high includes it.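

In this assay, thiophen-2-yl in place of thiophen-3-yl gave a 1.3-fold lower number from compound 3 to compound 4 (0.10 log units; within the scatter), and this step agrees with the same change on the other core: the same change on two cores in this assay, no change at the digits printed (within the scatter) from compound 2 to compound 1 and a 1.3-fold lower number (0.10 log units; within the scatter) from compound 3 to compound 4, 1.3-fold (0.10 log units) apart, within the scatter of two such steps Likewise, 3-chlorophenyl in place of 4-chlorophenyl gave a 4.4-fold lower number from compound 1 to compound 4 (0.64 log units; beyond the scatter), and this step also agrees with its counterpart: the same change on two cores in this assay, a 3.5-fold lower number (0.54 log units; beyond the scatter) from compound 2 to compound 3 and a 4.4-fold lower number (0.64 log units; beyond the scatter) from compound 1 to compound 4, 1.3-fold (0.10 log units) apart, within the scatter of two such steps Each change thus carried over between the two cores shown, but two pairs cannot show that it would hold on other cores, nor why it behaves as it does.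

The compounds shown leave open what an amine or a carboxylic acid in place of the chlorine of the 3-chlorophenyl group would do. They also leave open the effect of a methoxy group in place of the hydroxyl of the 3-hydroxyphenyl group.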